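The source may hold more compounds than are shown below. What is called first, only, known or untested is meant among the compounds shown, and "the series" means these compounds.

Working notes on the series. Compound 1 `Nc1nn2c(O)cc(CNNCCO)nc2c1[N+](=O)[O-]`, compound 2 `Nc1nn2c(O)cc(CNCCO)nc2c1[N+](=O)[O-]` and compound 3 `Nc1nn2c(O)cc(CNNC(N)S)nc2c1[N+](=O)[O-]` share one core and differ only in the chain on the amine nitrogen. In an ADME assay (Homo sapiens) for cytotoxicity (a higher number here means that more compound is tolerated, a lower number that less compound is tolerated), compound 1 gives only a limit, > 50 ug/mL. In this assay compound 2 likewise gives only a limit, > 50 ug/mL. In this assay compound 3 also gives only a limit, > 50 ug/mL. Compound 3 therefore stands nowhere apart from its neighbours: all three values sit at the same limit, as stated by the limit of > 50 ug/mL in this assay, at which 3 of the 3 values shown sit. The three measured steps carry no readable size: a step that the two limits leave unreadable from compound 1 to compound 2; a step that the two limits leave unreadable from compound 1 to compound 3; a step that the two limits leave unreadable from compound 2 to compound 3.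

Compound 4 `CCSC(N)NCc1cc(O)n2nc(N)c([N+](=O)[O-])c2n1` differs from compound 3 by amino(ethylsulfanyl)methyl in place of (amino(sulfanyl)methyl)amino on an amine nitrogen. The steps ending at compound 3, a step that the two limits leave unreadable from compound 1 to compound 3 and a step that the two limits leave unreadable from compound 2 to compound 3, are the ones that bear on this change, and they are unreadable because the limit of > 50 ug/mL in this assay, at which 3 of the 3 values shown sit, covers every value shown. Nothing in the series points to a direction, and exchanges of comparable size on this nitrogen have not moved any value off the limit. The expected step in this assay is a step that the limit leaves unreadable from compound 3 to compound 4, nothing beyond the scatter. Compound 4 is estimated at 60 ug/mL in this assay, within 25 ug/mL to 150 ug/mL, and is expected to return only a limit again.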

Compound 4, half-maximal cytotoxic concentration: > 50 ug/mL
Compound 4 was reported as a limit; the forecaster's own chance of this, stated with the estimate: 75%; the middle value lies beyond the limit too.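

In this assay compound 4 gives > 50 ug/mL, which is a limit. The steps to compound 4 from compound 1, compound 2 and compound 3 cannot be read, because all the values coincide: the limit of > 50 ug/mL in this assay, at which 4 of the 4 values shown sit.

The compounds shown leave open whether any of these chains on the amine nitrogen alters how much compound is tolerated.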